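A pyrazole swap on compound 3

The compounds below may be only part of what the source reports. "The series", "measured", "known", "first", "only" and "open" are said of these compounds alone.

In a functional assay on NCI-H1993 cells (Homo sapiens) for inhibition, read by CCK-8 assay, with a stated time of 72 h (a lower number here means a stronger inhibitor, a higher number a weaker inhibitor), compound 1 (`CC(c1c(F)cc2ncccc2c1F)n1cnc2ncc(-c3ccccc3)nc21`) gives 514 nM and compound 3 (`CC(NC/N=C/c1cnn(C)c1)c1ccc2ncccc2c1`) gives 197 nM as the lower of the two numbers, with a gap beyond the usual scatter of repeated measurements. Compound 2 (`COC(=O)c1ccc(-c2cnc3ncn(C(C)c4cc5cccnc5cc4C)c3n2)cc1F`) has no number: its entry reads "not determined" (no result reported) and so it cannot be ranked.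

Compound 4 (`CC(NC/N=C/c1ccnn1C)c1ccc2ncccc2c1`) has not yet been measured. It holds the same atoms as compound 3, joined differently (1-methyl-1H-pyrazol-5-yl in place of 1-methyl-1H-pyrazol-4-yl on a carbon with a double bond to nitrogen). Put simply, 1-methyl-1H-pyrazol-5-yl takes the place of 1-methyl-1H-pyrazol-4-yl on a carbon with a double bond to nitrogen.

Going by the values given here, no measured pair here shows what such a swap does, so any expectation is a cautious judgement from the structural change alone. The expected step is a modest rise in the number (a 2.0-fold higher number from compound 3 to compound 4 (0.31 log units; beyond the scatter)) toward a weaker inhibitor, close to the edge of the usual scatter. In this assay compound 4 is estimated at 400 nM with an expected range of 100 nM to 1500 nM around that figure.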

Compound 4, half-maximal inhibitory concentration: 3290 nM
Compound 4: the middle estimate sits 8.2-fold (0.92 log units) below what was measured; measured number outside the range, above it.
By their numbers in this assay, from the lowest: compound 3; then compound 1; then compound 4.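

In this assay the step is a 17-fold higher number from compound 3 to compound 4 (1.22 log units; beyond the scatter) and it comes from changing only how the same methylpyrazole ring is joined, on a carbon with a double bond to nitrogen. The group that leaves and the group that enters have the same heavy atoms, the same ring type and the same counts of hydrogen-bond donors and acceptors, so those counts do not predict the outcome at this place. The earlier compounds differ in more than one place and could not isolate this sensitivity to the point of attachment, and nothing available explains the size of the step.

Still open, going by these compounds, is how other rings at this place would compare, such as a pyridine or a pyrazole without the methyl group. On these data alone, it is also open whether a longer chain on the ring nitrogen would change the result for the 1-methyl-1H-pyrazol-5-yl group.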